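From 3-methylphenyl to 2-hydroxyethyl on the amide nitrogen

A few compounds are considered here, and "the series" means these few. Any claim that something is new, unique, unknown or untested is made for them only; others in the source may bear on it.

Measured in an ADME assay on Huh-7 cells (Homo sapiens) for cytotoxicity, read by a luciferase reporter and WST assay, with a stated time of 3 days; on this read-out lower numbers stand for higher toxicity in this test and higher numbers for lower toxicity in this test
- Compound 1 `Cc1ccc(-c2cc(NO)c(C(=O)Nc3ccccc3)c(=O)o2)cc1` gives > 20000 nM (a limit)
- Compound 2 `Cc1cccc(NC(=O)c2c(NO)cc(-c3ccccc3)oc2=O)c1` gives > 20000 nM (a limit)
- Compound 3 `CNC(=O)c1c(NO)cc(-c2ccc(C)cc2)oc1=O` gives > 20000 nM (a limit)

Compound 2 stands at > 20000 nM in this assay and that is a limit, not a number. Compound 4 `O=C(NCCO)c1c(NO)cc(-c2ccccc2)oc1=O` differs from it by 2-hydroxyethyl in place of 3-methylphenyl on an amide-type nitrogen and this reads as 2-hydroxyethyl in place of 3-methylphenyl on an amide-type nitrogen. The measured step that bears on this change is a step that the two limits leave unreadable from compound 1 to compound 3 and it gives no size. For the measured compounds named here, with the limit of > 20000 nM in this assay, at which 3 of the 3 values shown sit, as the only guide, no step beyond the scatter is expected in this assay in either direction. The expected change is a step that the limit leaves unreadable from compound 2 to compound 4 and this is only an estimate. Compound 4 is expected near 30000 nM (estimated range 15000 nM to 60000 nM) and will probably be reported only as a limit.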

Compound 4, half-maximal cytotoxic concentration: > 20000 nM
Compound 4 gave a limit, no number; the forecaster's own chance of this, stated with the estimate: 85%; the middle value is on the limit's open side.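

Compound 2 and compound 4 are both reported only as limits in this assay, and no step can be read between them. The compounds shown leave open at what concentration any of them would turn toxic to these cells.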